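The source may report more compounds than this note shows. Statements on the series, on what has been measured and on what is new or still open speak of the compounds shown alone.

Measured so far in a functional assay on HT-29 cells (Homo sapiens) for antiproliferative activity, read by sulforhodamine B assay, with a stated time of 48 h; on this read-out higher numbers stand for weaker inhibition and lower numbers for stronger inhibition:
- compound 1 `CCN1CCN(c2ccc(S(=O)(=O)Oc3cccc(OC)c3)cc2)C1=O`: 22000 nM
- compound 2 `CCCN1CCN(c2ccc(S(=O)(=O)Oc3c(Cl)cc(Cl)cc3Cl)cc2)C1=O`: 56000 nM

Of these two, compound 2 has the higher number, which makes it the weaker inhibitor here, and its gap to compound 1 lies beyond the usual scatter of repeated measurements. Next comes compound 3 `CCCN1CCN(c2ccc(S(=O)(=O)Oc3cccc(OC)c3)cc2)C1=O`, which has not yet been measured. It keeps the propyl chain of compound 2 and changes only the group on an oxygen whose other neighbour is the sulfonyl sulfur: 3-methoxyphenyl in place of 2,4,6-trichlorophenyl on an oxygen. In words, this puts 3-methoxyphenyl in place of 2,4,6-trichlorophenyl on an oxygen. Within the data shown here, no measured pair shows this swap alone, so the size of the step is a judgement. The closest guide is compound 1, which carries the same 3-methoxyphenyl with an ethyl chain instead of propyl and gives 22000 nM. A move toward a lower number is expected. The expected size of this move is a 2.8-fold lower number from compound 2 to compound 3 (0.45 log units; beyond the scatter). In this assay, compound 3 is expected at 20000 nM, with an estimated range from 8000 nM to 50000 nM.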

Compound 3, half-maximal inhibitory concentration: 25000 nM
Estimate against measurement, compound 3: 1.3-fold (0.10 log units) below; the measured number falls inside the stated range.
By their numbers in this assay, from the lowest: compounds 1 and 3 (each within the scatter of the next); then compound 2.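

In this assay, putting 3-methoxyphenyl in place of 2,4,6-trichlorophenyl on the oxygen bonded to the sulfonyl sulfur gives a 2.2-fold lower number from compound 2 to compound 3 (0.35 log units; beyond the scatter), the first measured effect of changing this group alone. The step from the ethyl chain to the propyl chain gives a 1.1-fold higher number from compound 1 to compound 3 (0.06 log units; within the scatter), so with 3-methoxyphenyl on that oxygen, these two chains cannot be told apart in this assay. Of the two places varied so far, only the group on the oxygen gives a step beyond the scatter, though each place has been tested just once, and nothing available explains why this swap has the effect it does.

The swap removes the three chlorine atoms and brings in the methoxy group in a single move, so these compounds cannot show which of the two matters, and a plain phenyl group on the oxygen would be needed to begin separating them. As far as these compounds go, it also remains open whether the chain has any effect beyond propyl, for example with a butyl chain, or whether the chain would matter with 2,4,6-trichlorophenyl on the oxygen.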